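This account rests on a few compounds, and the source may have more. Where it says the series, first, only, none or still open, it means among the compounds named here.

Measured so far: compound 1 `CNCc1c(OC)cc(Oc2cccc(Nc3ccccc3)c2)cc1OC` with 7430 nM, and compound 2 `CCN1CCN(Cc2c(OC)cc(Oc3cccc(Nc4ccccc4)c3)cc2OC)CC1` with > 20000 nM.

In a functional assay on HT-29 cells (Homo sapiens) for inhibition, read by MTT assay, with a stated time of 72 h (on this read-out higher numbers stand for weaker inhibition and lower numbers for stronger inhibition), compound 1 gives 7430 nM. Compound 2 reaches only a limit, > 20000 nM, so its position is known only as the limit of > 20000 nM in this assay, at which 1 of the 2 values shown sits. Among the compounds with values here, the single measured step, an at least 2.6-fold higher number from compound 1 to compound 2 (0.43 log units; beyond the scatter), replaced methylamino with 4-ethylpiperazin-1-yl. Compound 3 `COc1cc(Oc2cccc(Nc3ccccc3)c2)cc(OC)c1CNCc1ccc(Br)cc1` carries (4-bromobenzyl)amino in place of 4-ethylpiperazin-1-yl on a saturated chain carbon bound to an aromatic carbon, bringing back a secondary amine like that of compound 1. Compound 3 is therefore expected to give 8000 nM, within 3000 nM to 25000 nM. The expected step is an at least 2.5-fold lower number from compound 2 to compound 3 (0.39 log units; beyond the scatter).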

Compound 3, half-maximal inhibitory concentration: 3060 nM
The estimate for compound 3 lay 2.6-fold (0.42 log units) above the measured number; measured number inside the range.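

Replacing the hydrogen with 4-bromophenyl on a saturated chain carbon bound to an amine nitrogen gives a 2.4-fold lower number from compound 1 to compound 3 (0.39 log units; beyond the scatter), so this place accepts a substituent on the methylamino group without loss. The drop in activity seen with 4-ethylpiperazin-1-yl is therefore not shared by every replacement of methylamino, and (4-bromobenzyl)amino gives an at least 6.5-fold lower number from compound 2 to compound 3 (0.81 log units; beyond the scatter). Compound 2 stands only at a limit, so the true size of that step stays unknown: the limit of > 20000 nM in this assay, at which 1 of the 3 values shown sits.

Going by these compounds, what a plain benzylamino or a phenethylamino group would give at this place stays open. So does whether the bromine itself contributes to the step.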